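Hydrazone-linked adenosine analogues: aryl swap at the imine carbon

A few compounds are considered here, and "the series" means these few. Any claim that something is new, unique, unknown or untested is made for them only; others in the source may bear on it.

Three compounds of the series carry a measured number in an assay on CHO-K1 cells for displacement of a labelled ligand from adenosine receptor A1 (Homo sapiens), read by scintillation counting, with a stated time of 60 min; on this read-out higher numbers stand for weaker inhibition and lower numbers for stronger inhibition. Compound 1 `Nc1nc(N/N=C/c2cccc(OCc3ccccc3)c2)nc2c1ncn2[C@@H]1O[C@H](CO)[C@@H](O)[C@H]1O` gives 13 nM in this assay. Compound 2 `Nc1nc(N/N=C/c2ccc3ncccc3c2)nc2c1ncn2[C@@H]1O[C@H](CO)[C@@H](O)[C@H]1O` gives 9.8 nM in this assay; this is the lowest of the two numbers shown, and its gap to compound 1 lies within the scatter, so no order between the two is claimed. Compound 3 `Nc1nc(N/N=C/c2ccc(N(c3ccccc3)c3ccccc3)cc2)nc2c1ncn2[C@@H]1O[C@H](CO)[C@@H](O)[C@H]1O` reaches only the limit of this assay, > 10000 nM, and gives no number; this is the case recorded as the limit of > 10000 nM in this assay, at which 1 of the 3 values shown sits.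

Compound 4 `Nc1nc(N/N=C/c2ccc(Br)cn2)nc2c1ncn2[C@@H]1O[C@H](CO)[C@@H](O)[C@H]1O` has not yet been measured in this assay. Against compound 2 the change is 5-bromopyridin-2-yl in place of quinolin-6-yl on a carbon with a double bond to nitrogen. Within the data shown here, no pair of measured compounds differs in a single place, so the size of this step cannot be read from a measured counterpart. What the data show is that two aryl groups of moderate size, in compound 1 and compound 2, sit at similar numbers, while the large triarylamine in compound 3 sits at the limit.

For compound 4 the step of a 3.1-fold higher number from compound 2 to compound 4 (0.49 log units; beyond the scatter) is expected to be small, at most a modest move toward a higher number, and may well stay within the scatter. Compound 4 is estimated at 30 nM in this assay, with a range from 6 nM to 200 nM.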

Compound 4, inhibition constant: 4.7 nM
For compound 4 the middle estimate is 6.4-fold (0.81 log units) above the measured one; measured number below the stated range.
By their numbers in this assay, from the lowest: compound 4; then compounds 2 and 1 (each within the scatter of the next). At a limit, above all of these: compound 3.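

Among these compounds, replacing quinolin-6-yl with 5-bromopyridin-2-yl on a carbon with a double bond to nitrogen gives a 2.1-fold lower number from compound 2 to compound 4 (0.32 log units; beyond the scatter) in this assay, the first single-place change whose size can be read. The entering group has one aromatic ring and fewer heavy atoms than the leaving group, yet the number does not rise, so between these two compounds the second ring of quinolin-6-yl is not required at this position for a low number. No measured property shown here bears on this step, and the one recorded limit concerns a different compound.

All other steps among the compounds shown cannot be read, as those pairs differ in more than one place, and it remains open whether the bromine, the pyridine ring or the two together account for the lower number. Also open, on these data alone, is how a pyridin-2-yl group without bromine, or one carrying chlorine, a methoxy group or an amine in its place, would stand in this assay.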